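The compounds below may be only part of what the source reports. "The series", "measured", "known", "first", "only" and "open" are said of these compounds alone.

Compound 3 `Cc1nn(-c2ncnc3nc[nH]c23)c2c1C(C(=O)N(C)c1ccccc1)CC(=O)N2` stands at the top of the three measured numbers, giving 32 nM in a functional assay on HEK293 cells for agonist activity at G-protein coupled receptor 39 (Homo sapiens), read by scintillation proximity assay and inositol phosphate accumulation, with a stated time of 75 min, in the presence of a further agent that is not named here; on this read-out lower numbers stand for an effect already at smaller amounts and higher numbers for an effect only at larger amounts of compound. Its nearest neighbour is compound 2 `Cc1cc(C)n(CCOC2CC(=O)Nc3c2c(C)nn3-c2ncnc3nc[nH]c23)n1`, which gives 16 nM; the two lie within the scatter, as the step of a 2.0-fold higher number from compound 2 to compound 3 (0.30 log units; within the scatter) shows. Furthest off is compound 1 `Cc1nn(-c2ncnc3nc[nH]c23)c2c1C(OCc1ccccc1Cl)CC(=O)N2`, which gives 2 nM, and the step of a 16-fold higher number from compound 1 to compound 3 (1.20 log units; beyond the scatter) is large. Compound 4 `Cc1nn(-c2ncnc3nc[nH]c23)c2c1C(OCC(C)C)CC(=O)N2` has not yet been measured; it differs from compound 3 by isobutoxy in place of methyl(phenyl)carbamoyl on a saturated ring carbon.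

The step that bears most directly on this change is a 16-fold higher number from compound 1 to compound 3 (1.20 log units; beyond the scatter), where (2-chlorobenzyl)oxy giving way to methyl(phenyl)carbamoyl raised the number sharply. Compound 4 returns to a group linked through oxygen, but isobutoxy is smaller than (2-chlorobenzyl)oxy and carries no ring, so the gain seen in compound 1 need not carry over in full. The step of an 8.0-fold higher number from compound 1 to compound 2 (0.90 log units; beyond the scatter) shows that altering the group on the oxygen-linked side alone already cost a modest amount. Compound 4 is therefore expected to show a 3.2-fold lower number from compound 3 to compound 4 (0.51 log units; beyond the scatter), toward lower numbers. In this assay compound 4 is estimated at 10 nM, with a range from 3 nM to 40 nM.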

Compound 4, half-maximal effective concentration: 4 nM
For compound 4 the middle estimate is 2.5-fold (0.40 log units) above the measured one, within the range that was stated.
By their numbers in this assay, from the lowest: compounds 1 and 4 (each within the scatter of the next); then compounds 2 and 3 (each within the scatter of the next).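

In this assay, the step of an 8.0-fold lower number from compound 3 to compound 4 (0.90 log units; beyond the scatter) shows that at this saturated ring carbon isobutoxy, a group with no ring, can replace the larger methyl(phenyl)carbamoyl and still give a lower number, so a six-membered aromatic ring in the group is not required for a low number here. Among the groups linked through oxygen, the step of a 2.0-fold higher number from compound 1 to compound 4 (0.30 log units; within the scatter) lies within the scatter, which puts isopropyl level with 2-chlorophenyl on the saturated chain carbon, whereas the step of a 4.0-fold lower number from compound 2 to compound 4 (0.60 log units; beyond the scatter) sets compound 2 apart from this pair and shows that the oxygen link alone does not secure the low numbers. No measurement given here accounts for these differences.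

The change from compound 3 to compound 4 replaces the link and the group at once, so the share of the oxygen itself stays unresolved, and an amine linking the same isobutyl group would be needed to separate the two. From the compounds shown here alone, how far the size of the group can move in either direction also stays open, from a plain methoxy to a longer chain such as hexyloxy.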